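From a Carbamoylphenyl Ether to a Pentafluorophenyl Ether

A few compounds are considered here, and "the series" means these few. Any claim that something is new, unique, unknown or untested is made for them only; others in the source may bear on it.

Compound 1, `CC(C)[C@H](NC(=O)COc1cccc2ccccc12)C(=O)N[C@@H](CC(=O)O)C(=O)COc1ccc(-c2ccccc2)cc1`: in a functional assay on Jurkat cells (Homo sapiens) (on this read-out higher numbers stand for weaker inhibition and lower numbers for stronger inhibition), compound 1 gives 87900 nM.
Compound 2, `CC(C)[C@H](NC(=O)COc1cccc2ccccc12)C(=O)N[C@@H](CC(=O)O)C(=O)COc1ccc(C(N)=O)cc1`: in this assay compound 2 gives > 100000 nM, which is a limit of the assay and not a number.
Compound 3, `CC(C)[C@H](NC(=O)COc1cccc2ccccc12)C(=O)N[C@@H](CC(=O)O)C(=O)COc1cc(F)cc(F)c1`: in this assay compound 3 gives > 100000 nM, likewise a limit of the assay.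

Compound 2 thus stands at the limit of > 100000 nM in this assay, at which 2 of the 3 values shown sit, and only compound 1 returns a readable number, with the step of an at least 1.1-fold higher number from compound 1 to compound 2 (0.05 log units; that floor lies within the scatter). The unmeasured compound 4, `CC(C)[C@H](NC(=O)COc1cccc2ccccc12)C(=O)N[C@@H](CC(=O)O)C(=O)COc1c(F)c(F)c(F)c(F)c1F`, differs from compound 2 by 2,3,4,5,6-pentafluorophenyl in place of 4-carbamoylphenyl on an oxygen on a saturated carbon.

Among the measured compounds shown here, two measured steps bear on an exchange of the aromatic group on this oxygen. The step of an at least 1.1-fold higher number from compound 1 to compound 3 (0.05 log units; that floor lies within the scatter) shows a move to the limit, and the step that the two limits leave unreadable from compound 2 to compound 3 runs between two limits and cannot be read. Both the 4-carbamoylphenyl ether and the 3,5-difluorophenyl ether sit at the limit, and the 4-phenylphenyl ether of compound 1 is itself weak. For the measured compounds named here, no measured step therefore gives a direction beyond the scatter for the move in this assay; the expected step is a step that the limit leaves unreadable from compound 2 to compound 4. The account expects compound 4 to sit at the limit again, estimated at 150000 nM, with a range from 60000 nM to 400000 nM.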

Compound 4, half-maximal inhibitory concentration: 3050 nM
The estimate for compound 4 lay 49-fold (1.69 log units) above the measured number; measured number below the stated range.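

In this assay, the aromatic group on this oxygen turns out to be able to move the read-out well beyond the scatter, which the earlier ethers could not show: the exchange for 2,3,4,5,6-pentafluorophenyl gives an at least 32-fold lower number from compound 2 to compound 4 (1.51 log units; beyond the scatter), and the same group gives an at least 32-fold lower number from compound 3 to compound 4 (1.51 log units; beyond the scatter) and a 29-fold lower number from compound 1 to compound 4 (1.46 log units; beyond the scatter). Fluorine on the ring does not carry this change by itself, since compound 3, the 3,5-difluorophenyl ether, stays at its limit of the assay, and among the fluorinated ethers shown only compound 4 returns a readable number. Compound 2 also remains a limit and not a number, so the step from it gives only a floor: the limit of > 100000 nM in this assay, at which 2 of the 4 values shown sit.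

The compounds shown leave open whether all five fluorines are needed, as a 2,3,5,6-tetrafluorophenyl ether or a 4-fluorophenyl ether would show, and whether a pentachlorophenyl ether would behave in the same way. They also leave open whether the pentafluorophenyl ether keeps its number when the carboxylic acid of the shared core gives way to a methyl ester.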